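Hydroxy for chloro on the anilino series

This account rests on a few compounds, and the source may have more. Where it says the series, first, only, none or still open, it means among the compounds named here.

Values in a functional assay on HepG2 cells (Homo sapiens) for inhibition, read by MTT assay, with a stated time of 72 h; a higher number here means a weaker inhibitor, a lower number a stronger inhibitor:
- compound 1 `C#CCSc1nc(NCCC#N)c2ccncc2n1`: > 80000 nM, a limit of the assay and not a number
- compound 2 `C#CCSc1nc(Nc2ccccc2)c2ccncc2n1`: 29400 nM
- compound 3 `C#CCSc1nc(Nc2ccccc2Cl)c2ccncc2n1`: 17200 nM

Among the compounds with values here, compound 3 and compound 2 lie within the scatter of each other, and theirs are the only two actual numbers. Compound 4 `C#CCSc1nc(Nc2ccccc2O)c2ccncc2n1` has hydroxy in place of chloro on an aromatic carbon, ortho to a large group: hydroxy in place of chloro on an aromatic carbon. The closest measured change at this place is a 1.7-fold lower number from compound 2 to compound 3 (0.23 log units; within the scatter), with chloro in place of hydrogen. On that basis, no shift beyond the scatter is expected in this assay, and the expected step is a 1.2-fold higher number from compound 3 to compound 4 (0.07 log units; within the scatter). The estimate for compound 4 is 20000 nM, with an expected range of 8000 nM to 50000 nM.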

Compound 4, half-maximal inhibitory concentration: > 80000 nM
Compound 4: only a limit was reported; the forecaster's own chance of this, stated with the estimate: 15%; at least 4.0-fold (0.60 log units) between middle value and limit.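

In this assay, chloro in place of hydrogen at this position stayed within the scatter, whereas hydroxy is not tolerated in the same way: hydroxy in place of chloro gives an at least 4.6-fold higher number from compound 3 to compound 4 (0.66 log units; beyond the scatter), and hydroxy in place of hydrogen gives an at least 2.7-fold higher number from compound 2 to compound 4 (0.43 log units; beyond the scatter). The value of compound 4 is a limit and not a number: the limit of > 80000 nM in this assay, at which 2 of the 4 values shown sit. The step between compound 1 and compound 4 cannot be read.

Still open, as far as these compounds go, is whether an amine or a methoxy at this position behaves like hydroxy or like chloro.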